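This account rests on a few compounds, and the source may have more. Where it says the series, first, only, none or still open, it means among the compounds named here.

Measured compounds:
- Compound 1 `COc1cc2ncnc(Nc3cccc(Cl)c3)c2cc1OCCCCC(=O)Nc1ccc(S(N)(=O)=O)cc1`; in a functional assay on A549 cells (Homo sapiens) for antiproliferative activity, read by MTT assay, with a stated time of 72 h (a higher number here means a weaker inhibitor, a lower number a stronger inhibitor), compound 1 gives 11200 nM.
- Compound 2 `COc1ccc(Nc2ncnc3cc(OC)c(OCCCCC(=O)Nc4ccc(S(N)(=O)=O)cc4)cc23)cc1`; in this assay compound 2 gives > 40000 nM, which is a limit of the assay and not a number.

Compound 2 thus stands at the weak end of the pair, known only through (the limit of > 40000 nM in this assay, at which 1 of the 2 values shown sits). The single measured step, an at least 3.5-fold higher number from compound 1 to compound 2 (0.55 log units; beyond the scatter), runs toward compound 2 and is at least modest; its full size is not fixed by the numbers shown.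

Compound 3 `COc1cc2ncnc(Nc3cccc(Cl)c3F)c2cc1OCCCCC(=O)Nc1ccc(S(N)(=O)=O)cc1` is not yet measured. It differs from compound 2 in one place: 3-chloro-2-fluorophenyl in place of 4-methoxyphenyl on a nitrogen on an aromatic ring. The group leaving is the one that entered in the measured step, and the group entering is a halogenated phenyl close to that of compound 1, carrying an added fluorine. For the measured compounds named here, that step, read in reverse, is the only evidence bearing on the change. Compound 3 is therefore expected to move back toward the level of compound 1, the step of an at least 4.0-fold lower number from compound 2 to compound 3 (0.60 log units; beyond the scatter) being expected as a drop in this assay. Compound 3 is estimated at 10000 nM, within 3000 nM to 40000 nM.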

Compound 3, half-maximal inhibitory concentration: 10500 nM
Beside the measured number, compound 3's estimate is 1.1-fold (0.02 log units) below it, within the range that was stated.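

In this assay, for the compounds shown here, 3-chloro-2-fluorophenyl in place of 4-methoxyphenyl on the nitrogen gives an at least 3.8-fold lower number from compound 2 to compound 3 (0.58 log units; beyond the scatter), so a second halogenated phenyl now stands clear of the weak end of the series, and the 3-chlorophenyl of compound 1 is no longer the only such group on record. Fluoro in place of hydrogen on an aromatic carbon gives a 1.1-fold lower number from compound 1 to compound 3 (0.03 log units; within the scatter), so compound 1 and compound 3 cannot be told apart in this read-out, and this added fluorine shows no measurable effect on the number. The full size of the step from the methoxy compound stays unfixed because the value of compound 2 is a limit of the assay and not a number: the limit of > 40000 nM in this assay, at which 1 of the 3 values shown sits.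

Going by these compounds, whether an unsubstituted phenyl or a 4-chlorophenyl on the same nitrogen would fall with compound 1 and compound 3 or with compound 2 remains open, so the weak end cannot yet be tied to the methoxy group itself or to the absence of chlorine. Also open is how a shorter chain, or a carboxylic acid in place of the sulfonamide, would read, as all the compounds shown share that chain and that end group.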